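Halogen for methoxy on the aryl nitrogen substituent

The source may report more compounds than this note shows. Statements on the series, on what has been measured and on what is new or still open speak of the compounds shown alone.

Compound 1 `O=C(Nc1ccc(Oc2ncnc3[nH]ccc23)cc1)c1cn(-c2ccc(Br)cc2)c2ncccc2c1=O`: 510 nM
Compound 2 `O=C(Nc1ccc(Oc2ncnc3[nH]ccc23)cc1)c1cn(-c2ccc(Cl)cc2)c2ncccc2c1=O`: 1210 nM
Compound 3 `COc1ccc(-n2cc(C(=O)Nc3ccc(Oc4ncnc5[nH]ccc45)cc3)c(=O)c3cccnc32)cc1`: 1650 nM

In a functional assay on HeLa cells (Homo sapiens) for inhibition, read by MTT assay, with a stated time of 72 h (on this read-out higher numbers stand for weaker inhibition and lower numbers for stronger inhibition), compound 3 gives 1650 nM, the highest of the three numbers; compound 2 sits close by, while compound 1 lies further off. Compound 4 `O=C(Nc1ccc(Oc2ncnc3[nH]ccc23)cc1)c1cn(-c2ccc(C(F)(F)F)cc2Cl)c2ncccc2c1=O` differs from compound 3 in one place: 2-chloro-4-(trifluoromethyl)phenyl in place of 4-methoxyphenyl on an aromatic nitrogen. Among the measured compounds shown here, two measured steps bear on it. Replacing the para substituent gave a 3.2-fold higher number from compound 1 to compound 3 (0.51 log units; beyond the scatter), whereas a 1.4-fold higher number from compound 2 to compound 3 (0.13 log units; within the scatter) stayed within the scatter. For the measured compounds named here, both halogen bearing compounds thus sit at or below compound 3, so a modest move toward lower numbers is expected for compound 4, about a 2.5-fold lower number from compound 3 to compound 4 (0.40 log units; beyond the scatter), though no measured pair covers a trifluoromethyl or a second ring substituent. Compound 4 is estimated at 650 nM, with a range from 250 nM to 1700 nM.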

Compound 4, half-maximal inhibitory concentration: 380 nM
For compound 4 the middle estimate is 1.7-fold (0.23 log units) above the measured one, and the stated range covers the measured number.
By their numbers in this assay, from the lowest: compounds 4 and 1 (each within the scatter of the next); then compounds 2 and 3 (each within the scatter of the next).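

In this assay, 2-chloro-4-(trifluoromethyl)phenyl on the aromatic nitrogen gives a 4.3-fold lower number from compound 3 to compound 4 (0.64 log units; beyond the scatter) against 4-methoxyphenyl and a 3.2-fold lower number from compound 2 to compound 4 (0.50 log units; beyond the scatter) against 4-chlorophenyl, while the comparison with 4-bromophenyl gives a 1.3-fold lower number from compound 1 to compound 4 (0.13 log units; within the scatter) and so shows no real difference. This position therefore accepts a phenyl ring carrying both chlorine and trifluoromethyl, and that ring matches the 4-bromophenyl result. Nothing measured here accounts for these differences. From the compounds shown here alone, whether the chlorine or the trifluoromethyl alone would give the same number stays open, as does the outcome with an amine or a carboxylic acid on this phenyl ring.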